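The compounds below may be only part of what the source reports. "The series", "measured", "known", "first", "only" and "open" are said of these compounds alone.

Within the data shown here, compound 1 `CCCCOC1=C(C(=O)c2ccccc2)C(c2ccc(Br)cc2)N(CCCn2ccnc2)C1=O` gives 11600 nM in a functional assay on SAOS-2 cells (Homo sapiens) for antiproliferative activity, read by MTT assay, with a stated time of 72 h (on this read-out higher numbers stand for weaker inhibition and lower numbers for stronger inhibition), the lowest of the three numbers measured so far. Compound 2 `O=C(C1=C(Nc2ccc(F)cc2)C(=O)N(CCCn2ccnc2)C1c1ccc(Br)cc1)c1ccccc1` gives 32700 nM in this assay, and compound 3 `O=C(C1=C(Nc2ccc(Br)cc2)C(=O)N(CCCn2ccnc2)C1c1ccc(Br)cc1)c1ccccc1` gives 23800 nM. Compound 4 `O=C(C1=C(Nc2cccc(Br)c2)C(=O)N(CCCn2ccnc2)C1c1ccc(Br)cc1)c1ccccc1` differs from compound 1 by (3-bromophenyl)amino in place of butoxy on a double-bonded ring carbon. Among the measured compounds shown here, two measured steps bear on this change, since both also replaced the butoxy group of compound 1: a 2.8-fold higher number from compound 1 to compound 2 (0.45 log units; beyond the scatter) and a 2.1-fold higher number from compound 1 to compound 3 (0.31 log units; beyond the scatter), each modest and beyond the scatter. Between the two halogens, a 1.4-fold lower number from compound 2 to compound 3 (0.14 log units; within the scatter). A step of similar size toward a higher number is therefore expected for compound 4, namely a 2.4-fold higher number from compound 1 to compound 4 (0.38 log units; beyond the scatter). Compound 4 is accordingly estimated at 28000 nM, within a range from 12000 nM to 65000 nM.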

Compound 4, half-maximal inhibitory concentration: 9090 nM
For compound 4 the middle estimate is 3.1-fold (0.49 log units) above the measured one, and the stated range ends above it.
By their numbers in this assay, from the lowest: compounds 4 and 1 (each within the scatter of the next); then compounds 3 and 2 (each within the scatter of the next).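

In this assay, replacing butoxy with an arylamino group does not always raise the number: a 1.3-fold lower number from compound 1 to compound 4 (0.11 log units; within the scatter). The outcome at this position depends on the substituent on the phenyl ring, with a 2.6-fold lower number from compound 3 to compound 4 (0.42 log units; beyond the scatter) and a 3.6-fold lower number from compound 2 to compound 4 (0.56 log units; beyond the scatter), so the 3-bromophenyl group separates from both the 4-bromophenyl and 4-fluorophenyl groups. Nothing available explains this difference. Going by these compounds, it remains open whether a 3-chlorophenyl or 3-methoxyphenyl group on the amine nitrogen would match the 3-bromophenyl group of compound 4. On these data alone, the effect of a butylamino group here is also open.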